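Aryl amide swaps on a shared isatin-hydrazone core

The compounds below may be only part of what the source reports. "The series", "measured", "known", "first", "only" and "open" are said of these compounds alone.

Measured so far in a functional assay on MCF7 cells (Homo sapiens) for cytotoxicity, read by MTT assay, with a stated time of 48 h; on this read-out higher numbers stand for an effect only at larger amounts of compound and lower numbers for an effect already at smaller amounts:
- compound 1 `CC(=O)Nc1ccc(NC(=O)CN2C(=O)/C(=N\NC(=O)Cn3ccc(=O)c(O)c3C)c3ccccc32)cc1`: 51900 nM
- compound 2 `Cc1c(O)c(=O)ccn1CC(=O)N/N=C1\C(=O)N(CC(=O)Nc2ccccc2Cl)c2ccccc21`: 46400 nM

Compound 2 stands alongside compound 1; the step (a 1.1-fold lower number from compound 1 to compound 2 (0.05 log units; within the scatter)) lies within the scatter, so the two show no difference.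

Compound 3 `Cc1cccc(NC(=O)CN2C(=O)/C(=N\NC(=O)Cn3ccc(=O)c(O)c3C)c3ccccc32)c1C` differs from compound 2 by 2,3-dimethylphenyl in place of 2-chlorophenyl on an amide-type nitrogen. Among the measured compounds shown here, only one measured step bears on this position, a 1.1-fold lower number from compound 1 to compound 2 (0.05 log units; within the scatter), and it was flat; nothing suggests that another aryl swap there moves the number beyond the scatter. The step from compound 2 to compound 3 is therefore expected as a 1.1-fold higher number from compound 2 to compound 3 (0.03 log units; within the scatter). Compound 3 is estimated at 50000 nM, range 20000 nM to 125000 nM.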

Compound 3, half-maximal effective concentration: 51900 nM
Estimate against measurement, compound 3: 1.0-fold (0.02 log units) below; the measured number falls inside the stated range.
By their numbers in this assay, from the lowest: compounds 2, 1 and 3 (each within the scatter of the next).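

Both new steps stay within the scatter in this assay: a 1.1-fold higher number from compound 2 to compound 3 (0.05 log units; within the scatter) and no change at the digits printed from compound 1 to compound 3 (within the scatter). The amide-type nitrogen now carries 4-acetamidophenyl, 2-chlorophenyl and 2,3-dimethylphenyl with no difference among compounds 1, 2 and 3, so the flat result from the first step also holds for a dimethyl-substituted aryl group. Nothing available explains this flat result. Going by these compounds, whether a carboxylic acid or an amine on the aryl ring, or a longer chain in its place, would move the number remains open. The compounds shown also leave open how changes elsewhere on the shared core would read.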